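A Phenyl Group Replacing the Oxime on the Carbamate

A few compounds are considered here, and "the series" means these few. Any claim that something is new, unique, unknown or untested is made for them only; others in the source may bear on it.

Of the compounds shown here, two sharing one core have been measured in an assay on H4 cells for inhibition of Fatty-acid amide hydrolase 1 (Homo sapiens); on this read-out higher numbers stand for weaker inhibition and lower numbers for stronger inhibition. Compound 1 `CCCCCCOc1ccc(NC(=O)ON=C(C)C)cc1` gives 18 nM and stands as the higher of the two numbers. Compound 2 `CCCCCCCCCCCCOc1ccc(NC(=O)ON=C(C)C)cc1` gives 5 nM, and the step of a 3.6-fold lower number from compound 1 to compound 2 (0.56 log units; beyond the scatter) comes from a longer chain on the oxygen of the aromatic ring.

Compound 3 `CCCCCCOc1ccc(NC(=O)Oc2ccccc2)cc1` has not yet been measured. It differs from compound 1 in this way: a group of 6 heavy atoms (6 carbon; one six-membered aromatic ring of carbon only) in place of a group of 4 heavy atoms (3 carbon, 1 nitrogen; no ring), on an oxygen next to a carbonyl group. Going by the values given here, the only measured step, from compound 1 to compound 2, changes the chain and leaves the carbamate oxygen untouched, so it does not bear on the change in compound 3. Among the compounds with values here, no measured pair shows what exchanging the oxime group for a phenyl group does here, and the expectation rests on compound 1 alone as the starting point.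

Without a guiding step, compound 3 is expected to stay close to compound 1, the step of a 1.2-fold lower number from compound 1 to compound 3 (0.08 log units; within the scatter) being within or only modestly beyond the scatter. The estimate for compound 3 in this assay is 15 nM, with a range from 3 nM to 80 nM.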

Compound 3, half-maximal inhibitory concentration: 31 nM
Compound 3: the middle estimate sits 2.1-fold (0.32 log units) below what was measured, within the range that was stated.
By their numbers in this assay, from the lowest: compound 2; then compounds 1 and 3 (each within the scatter of the next).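

In this assay, exchanging the oxime group for phenyl, on an oxygen next to a carbonyl group, gives a 1.7-fold higher number from compound 1 to compound 3 (0.24 log units; within the scatter) and so leaves the two compounds indistinguishable on this read-out. Going by these compounds alone, this is the first look at this position, since the earlier step changed only the chain, and this single pair shows that a ring of carbon only can stand where a group with a nitrogen, a double bond and a hydrogen-bond acceptor stood, without a change beyond the scatter. No measurement at hand explains why the two groups give such similar numbers.

On these data alone, it remains open whether a phenyl ring carrying a further group, such as a chlorine or a methoxy, or a small group such as methyl on the same oxygen, would stay in this range. Also open, as far as these compounds go, is whether the longer chain of compound 2 would lower the number on the phenyl carbamate as it does on the oxime carbamate, a question that compound 3 alone cannot settle.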